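Swapping the aryl group on the sulfonyl sulfur

A few compounds are considered here, and "the series" means these few. Any claim that something is new, unique, unknown or untested is made for them only; others in the source may bear on it.

Within the data shown here, in a functional assay on DU-145 cells (Homo sapiens) for inhibition, read by trypan blue exclusion, with a stated time of 96 h (a lower number here means a stronger inhibitor of growth, a higher number a weaker inhibitor of growth), compound 2 `COc1ccc(S(=O)(=O)/C(=C/c2ccc(Br)cc2)C(=O)c2ccc(Br)cc2)cc1` gives 6000 nM, the lower of the two numbers so far. Compound 1 `O=C(/C(=C\c1c(O)cc(O)cc1O)S(=O)(=O)c1ccccc1Br)c1ccc(Br)cc1` gives 50000 nM, a gap beyond the scatter. Compound 3 `O=C(/C(=C\c1ccc(Br)cc1)S(=O)(=O)c1ccccc1Br)c1ccc(Br)cc1` follows from compound 2 by one change, 2-bromophenyl in place of 4-methoxyphenyl on a sulfonyl sulfur. Among the measured compounds shown here, no single-change step has been measured, so the size of this one rests on little. Compound 1 also carries 2-bromophenyl on a sulfonyl sulfur and sits at 50000 nM, yet it differs from compound 3 elsewhere as well, so it supports only a slight lean towards weaker growth inhibition in this assay. The expected change, a 1.3-fold higher number from compound 2 to compound 3 (0.12 log units; within the scatter), is small and probably within the scatter. For compound 3 the estimate is 8000 nM, with an expected range of 2500 nM to 30000 nM.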

Compound 3, concentration for 50% growth inhibition: 1000 nM
The estimate for compound 3 lay 8.0-fold (0.90 log units) above the measured number, and the stated range ends above it.
By their numbers in this assay, from the lowest: compound 3; then compound 2; then compound 1.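

In this assay the aryl group on the sulfonyl sulfur now has a single-change reading of its own: 2-bromophenyl in place of 4-methoxyphenyl gives a 6.0-fold lower number from compound 2 to compound 3 (0.78 log units; beyond the scatter) on an otherwise unchanged core. With 2-bromophenyl held on the sulfonyl sulfur, 4-bromophenyl in place of 2,4,6-trihydroxyphenyl on a double-bonded chain carbon bound to a double-bonded chain carbon gives a 50-fold lower number from compound 1 to compound 3 (1.70 log units; beyond the scatter), so the series responds to changes in both places. Nothing at hand accounts for either step.

Among these compounds, with only two groups read on the sulfonyl sulfur, it stays open whether the step follows the bromine, where it sits on the ring, or the absence of the methoxy group. On these data alone, how plain phenyl, or an aryl group carrying an amine or a carboxylic acid, would read there is also open.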